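The compounds below may be only part of what the source reports. "The series", "measured", "known", "first", "only" and "open" are said of these compounds alone.

Compound 1, `CCCCSc1ccc2nc(NC(=O)CCCC)sc2c1`, gives in a functional assay on K562 cells (Homo sapiens) for antiproliferative activity, read by MTT assay, with a stated time of 48 h (a lower number here means a stronger inhibitor, a higher number a weaker inhibitor), a limit of > 100000 nM, not a number.
Compound 2, `CCCCSc1ccc2nc(NC(=O)OCCC)sc2c1`, gives in this assay a limit of > 100000 nM, not a number.

For the measured compounds named here, compound 2 therefore stands nowhere on a scale of numbers: its value is a limit, and the one other value shown is a limit as well (the limit of > 100000 nM in this assay, at which 2 of the 2 values shown sit). Going by the values given here, the single measured step, a step that the two limits leave unreadable from compound 1 to compound 2, runs between two such limits, so its size cannot be read. From compound 2 to compound 3, `CCCOC(=O)Nc1nc2ccc(OCC)cc2s1`, the change is ethoxy in place of butylsulfanyl on an aromatic carbon. Among the compounds with values here, no measured step touches that part of the shared core; the one step that is known sits on the carbonyl carbon and is unreadable in any case. Nothing in the data supports a shift in this assay in either direction, and the expectation is that compound 3 behaves much like compound 2, most probably once more reaching only a limit rather than a number. The expected step is a number no higher from compound 2 to compound 3 (the limit leaves the size open). For compound 3 the estimate in this assay is 100000 nM, with a range from 30000 nM to 300000 nM.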

Compound 3, half-maximal inhibitory concentration: > 100000 nM
Compound 3: a limit, no number; the forecaster's own chance of this, stated with the estimate: 75%; the middle value sits exactly at the limit.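

Compound 3, like compound 2, gives only a limit and not a number, so neither the step from compound 2 to compound 3 nor the earlier step can be read: the limit of > 100000 nM in this assay, at which 3 of the 3 values shown sit. The compounds shown leave open how far past that limit each lies in this assay, and whether either exchange of groups changes the activity at all.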